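Trifluoromethyl to Cyano: Expecting Compound 4

This account rests on a few compounds, and the source may have more. Where it says the series, first, only, none or still open, it means among the compounds named here.

Compound 1 `CC(=O)/C(=N\Nc1ccccc1[N+](=O)[O-])N(C)c1cccc(Cl)c1`: 8600 nM
Compound 2 `CC(=O)/C(=N\Nc1ccccc1C(F)(F)F)Nc1cccc(Cl)c1`: 538 nM; 538 nM (2 entries)
Compound 3 `CC(=O)/C(=N\Nc1ccccc1C(F)(F)F)N(C)c1cccc(Cl)c1`: > 10000 nM

All three were tested in an assay on isolated protein for binding affinity to corticotropin-releasing factor receptor 1 (Homo sapiens); a lower number here means a stronger inhibitor, a higher number a weaker inhibitor. Compound 1, carrying a nitro group, gives 8600 nM. Compound 2, which has trifluoromethyl but no methyl on the nitrogen, gives 538 nM; 538 nM (2 entries). For compound 3 this assay reports only a limit, > 10000 nM, not a number; it sits at the limit of > 10000 nM in this assay, at which 1 of the 3 values shown sits. For the measured compounds named here, the one step that can be measured here is an at least 1.1-fold higher number from compound 1 to compound 3 (0.06 log units; that floor lies within the scatter), so trifluoromethyl in place of nitro did not bring the methylated compound any closer to a strong result.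

Compound 4 `CC(=O)/C(=N\Nc1ccccc1C#N)N(C)c1cccc(Cl)c1` changes the same position again: cyano in place of trifluoromethyl on an aromatic carbon. Going by the values given here, only the step from compound 1 to compound 3 bears on this, and it was small and at the edge of the limit. Two groups at this position have left the methylated compound weak, and nothing suggests cyano would behave differently. Compound 4 is therefore estimated at 9000 nM, with a range of 2500 nM to 30000 nM. That estimate means an expected at least 1.1-fold lower number from compound 3 to compound 4 (0.04 log units; that floor lies within the scatter), and a fair chance that this assay again reports only a limit.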

Compound 4, inhibition constant: > 10000 nM
Compound 4 ended at the assay's limit; the forecaster's own chance of this, stated with the estimate: 45%; middle value at least 1.1-fold (0.04 log units) from the limit.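

In this assay compound 4 gives > 10000 nM, which is a limit of the assay and not a number. Setting cyano in place of nitro on the methylated compound produces an at least 1.1-fold higher number from compound 1 to compound 4 (0.06 log units; that floor lies within the scatter), so cyano, now the third group tried at this position on that compound, brings no measurable gain over nitro. The step between compound 3 and compound 4 cannot be read, since both compounds stand at the same limit, and trifluoromethyl and cyano cannot be ranked against each other: the limit of > 10000 nM in this assay, at which 2 of the 4 values shown sit.

From the compounds shown here alone, it remains open whether an amine or a carboxylic acid at this position would bring the methylated compound clear of that limit. Going by these compounds, it is also open how cyano would fare without the methyl on the nitrogen, the form in which compound 2, with trifluoromethyl, gives 538 nM; 538 nM (2 entries).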